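The source may hold more compounds than are shown below. What is called first, only, known or untested is meant among the compounds shown, and "the series" means these compounds.

In a functional assay on HCT-116 cells (Homo sapiens) for antiproliferative activity, read by MTT assay, with a stated time of 48 h (a lower number here means a stronger inhibitor, a higher number a weaker inhibitor), three close relatives built on one shared core have been measured. Compound 1 `Cc1cnc(Nc2ccc([N+](=O)[O-])cc2)nc1Nc1nc2ccccc2s1` gives 6330 nM. Compound 2 `Cc1cnc(Nc2ccc(Cl)cc2)nc1Nc1nc2ccccc2s1` reaches only a limit of the assay, > 50000 nM. Compound 3 `COc1ccc(Nc2ncc(C)c(Nc3nc4ccccc4s3)n2)cc1` likewise shows only a limit, > 50000 nM. The two steps away from compound 1 are both beyond the scatter: an at least 7.8-fold higher number from compound 1 to compound 2 (0.89 log units; beyond the scatter) and an at least 7.8-fold higher number from compound 1 to compound 3 (0.89 log units; beyond the scatter). The step between compound 2 and compound 3 cannot be read, a step that the two limits leave unreadable from compound 2 to compound 3; this follows from the limit of > 50000 nM in this assay, at which 2 of the 3 values shown sit. Compound 3 therefore stands with no number of its own, only a limit, and cannot be set in order against compound 2.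

Compound 4 `Cc1cnc(Nc2cccc(F)c2)nc1Nc1nc2ccccc2s1` has not yet been measured in this assay. It differs from compound 3 in one place: 3-fluorophenyl in place of 4-methoxyphenyl on a nitrogen on an aromatic ring. The measured steps that bear on this change are the two in which the group on the aromatic carbon was exchanged, an at least 7.8-fold higher number from compound 1 to compound 2 (0.89 log units; beyond the scatter) and an at least 7.8-fold higher number from compound 1 to compound 3 (0.89 log units; beyond the scatter); both the chloro partner and the methoxy partner fell to the limit. A halogen enters once more here, so compound 4 is expected to stay near that limit, with an at least 1.2-fold lower number from compound 3 to compound 4 (0.09 log units; that floor lies within the scatter). The estimate for compound 4 is 40000 nM, within 8000 nM to 200000 nM.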

Compound 4, half-maximal inhibitory concentration: 27800 nM
Estimate against measurement, compound 4: 1.4-fold (0.16 log units) above; low and high end bracket the measured number.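

In this assay compound 4 joins compound 1 in giving a number rather than a limit, so a group on this nitrogen other than 4-nitrophenyl can now be read on the scale of the assay. The steps of an at least 1.7-fold lower number from compound 3 to compound 4 (0.25 log units; that floor lies within the scatter) and an at least 1.7-fold lower number from compound 2 to compound 4 (0.25 log units; that floor lies within the scatter) are only floors, so the size of the gap from 3-fluorophenyl to either 4-methoxyphenyl or 4-chlorophenyl stays hidden behind a limit: the limit of > 50000 nM in this assay, at which 2 of the 4 values shown sit.
For the compounds shown here, the one step with a number at both ends, a 4.4-fold higher number from compound 1 to compound 4 (0.64 log units; beyond the scatter), shows that 3-fluorophenyl, although measurable, does not reach the level of 4-nitrophenyl at this place.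

Because 3-fluorophenyl differs from each of the other three groups both in its substituent and in where that substituent sits on the ring, the compounds shown cannot separate the effect of the atom from the effect of its place. They also leave open how the number would read with an amine, a carboxylic acid or a nitrile on this phenyl ring in place of the fluorine.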